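From Isopropyl Amide to Hydroxamic Acid on a Cyclopropyl

The compounds below may be only part of what the source reports. "The series", "measured", "known", "first", "only" and "open" are said of these compounds alone.

Of the compounds shown here, three with a shared core have been measured in a functional assay on CHO cells for agonist activity at Free fatty acid receptor 1 (Homo sapiens); a lower number here means that less compound is needed, a higher number that more compound is needed for the effect. Compound 1 `Cc1nc(-c2ccc(C(F)(F)F)cc2)sc1CNc1ccc(OCC(=O)O)cc1` gives 288 nM. Compound 2 `Cc1nc(-c2ccc(C(F)(F)F)cc2)sc1CNc1ccc(CCC(N)=O)cc1` gives 12.9 nM. Compound 3 `Cc1nc(-c2ccc(C(F)(F)F)cc2)sc1CNc1ccc(CCC(=O)NC(C)C)cc1` gives 100 nM, the second highest of the three numbers, with compound 2 furthest from it and compound 1 nearest.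

The new compound 4 `Cc1nc(-c2ccc(C(F)(F)F)cc2)sc1CNc1ccc([C@H]2C[C@@H]2C(=O)NO)cc1` differs from compound 3 in one place: 2-(hydroxycarbamoyl)cyclopropyl in place of 2-(isopropylcarbamoyl)ethyl on an aromatic carbon. Going by the values given here, two measured steps bear on this. Among the compounds with values here, the step of a 2.9-fold lower number from compound 1 to compound 3 (0.46 log units; beyond the scatter) was modest, and the step of a 7.8-fold higher number from compound 2 to compound 3 (0.89 log units; beyond the scatter) was also modest, the only change there being an isopropyl on the amide nitrogen. Within the data shown here, compound 4 again carries a hydrogen on that nitrogen, as compound 2 does, together with a hydroxyl, while its three-membered ring has no counterpart among the measured compounds. On that basis a modestly lower number is expected, a 3.3-fold lower number from compound 3 to compound 4 (0.52 log units; beyond the scatter). Compound 4 is therefore estimated at 30 nM, with a range from 8 nM to 120 nM.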

Compound 4, half-maximal effective concentration: 6.92 nM
Beside the measured number, compound 4's estimate is 4.3-fold (0.64 log units) above it; measured number below the stated range.
By their numbers in this assay, from the lowest: compounds 4 and 2 (each within the scatter of the next); then compound 3; then compound 1.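

In this assay the new group gives a 14-fold lower number from compound 3 to compound 4 (1.16 log units; beyond the scatter) and, against the carboxymethoxy group, a 42-fold lower number from compound 1 to compound 4 (1.62 log units; beyond the scatter), so this place, para to a large group, tolerates a three-membered ring together with a hydroxyl on the amide nitrogen. Set against the 2-carbamoylethyl group, the same change gives a 1.9-fold lower number from compound 2 to compound 4 (0.27 log units; within the scatter), so the two groups cannot be told apart in this assay, and the isopropyl group is the one that stands out from them. No supporting measurement is available to explain these shifts.

As far as these compounds go, compound 4 changes the chain and the amide nitrogen at once, so the share of each remains open. A cyclopropyl carrying a plain primary amide or a carboxylic acid, a straight 2-(hydroxycarbamoyl)ethyl chain, and the mirror-image ring would each help separate them.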